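The compounds below may be only part of what the source reports. "The series", "measured", "known", "first", "only" and "open" are said of these compounds alone.

Compounds measured:
compound 1 `Cc1ccc2c(c1)oc(=O)n2CCOc1ccnc2cc(-c3cnn(C)c3)ccc12` — 35 nM
compound 2 `COc1ccc2c(OCCn3c(=O)oc4cc(-c5cnn(C)c5)ccc43)ccnc2c1` — 100 nM

In a functional assay on EBC-1 cells (Homo sapiens) for inhibition, read by sulforhodamine B assay, with a stated time of 72 h (a lower number here means a stronger inhibitor, a higher number a weaker inhibitor), compound 2 gives the higher of the two numbers, compound 1 the lower, and the gap between them lies beyond the scatter. Compound 3 `Cn1cc(-c2ccc3c(OCCn4c(=O)oc5cc(-c6cnn(C)c6)ccc54)ccnc3c2)cn1` is not yet measured. It differs from compound 2 in one place: 1-methyl-1H-pyrazol-4-yl in place of methoxy on an aromatic carbon. Within the data shown here, no measured pair shows this change, so its size is unknown; a moderate step toward a lower number is expected, though a result within the scatter of compound 2 would not surprise. For compound 3 the estimated value is 50 nM, with a range of 20 nM to 150 nM, an expected step of a 2.0-fold lower number from compound 2 to compound 3 (0.30 log units; within the scatter).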

Compound 3, half-maximal inhibitory concentration: 5 nM
Beside the measured number, compound 3's estimate is 10-fold (1.00 log units) above it; the whole stated range lies above it.
By their numbers in this assay, from the lowest: compound 3; then compound 1; then compound 2.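

In this assay, 1-methyl-1H-pyrazol-4-yl in place of methoxy on an aromatic carbon gives a 20-fold lower number from compound 2 to compound 3 (1.30 log units; beyond the scatter), a large step, which shows that this position accepts a five-membered aromatic ring and gains from it. The same group in place of methyl gives a 7.0-fold lower number from compound 1 to compound 3 (0.85 log units; beyond the scatter), a modest step, so both smaller groups fall short of it. From the compounds shown here alone, how an amine, a morpholine or an unmethylated pyrazole would compare at this position stays open. Nothing shown here accounts for the gain.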